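This account rests on a few compounds, and the source may have more. Where it says the series, first, only, none or still open, it means among the compounds named here.

Of the compounds shown here, three have been measured so far, all on the same core. Compound 1 `COc1cc(-c2cc(/C=C/C(=O)c3ccc(Cl)c(Cl)c3)[nH]n2)cc(OC)c1OC` gives 19% in a functional assay on KM12 cells (Homo sapiens) for cytotoxicity, read by sulforhodamine B assay, with a stated time of 48 h, tested at 10 uM; on this read-out higher numbers stand for a weaker effect at the one concentration tested and lower numbers for a stronger effect. Compound 2 `COc1ccc(-c2cc(/C=C/C(=O)c3ccc(N)cc3)[nH]n2)cc1` gives -67% in this assay, and compound 3 `COc1ccc(C(=O)/C=C/c2cc(-c3cc(OC)c(OC)c(OC)c3)n[nH]2)cc1` gives -88% in this assay, the lowest of the three numbers, with compound 2 nearest to it and compound 1 furthest away.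

Compound 4 `COc1cc(-c2cc(/C=C/C(=O)c3ccc(F)c(F)c3)[nH]n2)cc(OC)c1OC` has not yet been measured. It differs from compound 3 by 3,4-difluorophenyl in place of 4-methoxyphenyl on a carbonyl carbon. Within the data shown here, one measured step bears on this change, and it ran in the opposite direction: a number 107 percentage points lower from compound 1 to compound 3 (beyond the scatter). Since compound 4 moves back from 4-methoxyphenyl to a ring bearing two halogens, though fluorine rather than chlorine, a large rise is expected, probably not the full reversal. Compound 4 is therefore expected to give about -10%, between -60% and 40%, in this assay. The expected step is a number 78 percentage points higher from compound 3 to compound 4 (beyond the scatter).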

Compound 4, a percentage reported as activity, at one concentration (the size of the read-out at that concentration, not a potency): 3%
Compound 4: middle estimate off by 13 percentage points, on the low side; the measured number falls inside the stated range.
By their numbers in this assay, from the lowest: compound 3; then compound 2; then compound 4; then compound 1.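

In this assay, the change on the carbonyl carbon gives a large step with a second dihalogenated ring: the step is a number 91 percentage points higher from compound 3 to compound 4 (beyond the scatter) when 3,4-difluorophenyl replaces 4-methoxyphenyl. The earlier rise is therefore not confined to 3,4-dichlorophenyl, yet the two halogenated rings do not read alike, the step being a number 16 percentage points lower from compound 1 to compound 4 (beyond the scatter) for fluorine in place of chlorine. No available evidence accounts for either step. As far as these compounds go, whether a phenyl ring bearing a nitrile or a carboxylic acid would read nearer compound 3 or compound 4 remains open.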